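Cyclic carbamate in place of the open carbamate on the core

The source may hold more compounds than are shown below. What is called first, only, known or untested is meant among the compounds shown, and "the series" means these compounds.

Measured so far in an assay on cells for activation of Guanylate cyclase soluble subunit alpha-1 (Rattus norvegicus), read by cGMP accumulation and immunoassay, with a stated time of 10 min; a lower number here means that less compound is needed, a higher number that more compound is needed for the effect:
compound 1 `CCN(C(=O)OC)c1c(N)nc(-c2nn(Cc3ccccc3F)c3ncccc23)nc1N` gives 0.2 uM
compound 2 `Nc1nc(-c2nn(Cc3ccccc3F)c3ncccc23)nc(N)c1NC(=O)OC1CCC1` gives 0.2 uM
compound 3 `Nc1nc(-c2nn(Cc3ccccc3F)c3ncccc23)nc(N)c1NC(=O)OC1COC1` gives 2.3 uM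

Compound 1 stands level with compound 2 at the digits shown; together they carry the lowest of the three numbers, and compound 3 stands furthest from compound 1 with a higher number.

The step under consideration leads from compound 1 to compound 4 `Nc1nc(-c2nn(Cc3ccccc3F)c3ncccc23)nc(N)c1N1C[C@H](C(F)(F)F)OC1=O`. The change is a group of 10 heavy atoms (4 carbon, 1 nitrogen, 2 oxygen, 3 fluorine; one five-membered non-aromatic ring with 2 hetero atoms) in place of a group of 7 heavy atoms (4 carbon, 1 nitrogen, 2 oxygen; no ring), on an aromatic carbon. The group that leaves is the ethyl(methoxycarbonyl)amino; what enters has no common name and carries one five-membered non-aromatic ring with 2 hetero atoms and 1 defined stereocentre, on the same aromatic carbon.

Among the compounds with values here, two measured steps bear on it. Step no change at the digits printed from compound 1 to compound 2 (within the scatter) shows that the open carbamate can be rebuilt without a shift beyond the scatter. Step a 12-fold higher number from compound 1 to compound 3 (1.06 log units; beyond the scatter) shows that one variant of the carbamate ester did move the number markedly higher. The entering group of compound 4 is neither of these: the carbamate is closed into a ring and a trifluoromethyl is added. The expectation for compound 4 is therefore a modest rise, a 3.0-fold higher number from compound 1 to compound 4 (0.48 log units; beyond the scatter), with wide uncertainty.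

The estimate for compound 4 in this assay is 0.6 uM, within 0.15 uM to 3 uM.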

Compound 4, minimum effective concentration: 0.2 uM
Beside the measured number, compound 4's estimate is 3.0-fold (0.48 log units) above it; the measured number falls inside the stated range.
By their numbers in this assay, from the lowest: compounds 1, 2 and 4 (each within the scatter of the next); then compound 3.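

In this assay the carbamate on the aromatic carbon ortho to two amino groups can be closed into a five-membered ring bearing a trifluoromethyl and a defined stereocentre, with no change at the digits printed from compound 1 to compound 4 (within the scatter) as the outcome, so this position accepts a cyclic form as well as the open ethyl(methoxycarbonyl)amino group. The comparison with the cyclobutyl carbamate reads the same, no change at the digits printed from compound 2 to compound 4 (within the scatter) being the result, whereas the oxetan-3-yl carbamate stays apart, with a 12-fold lower number from compound 3 to compound 4 (1.06 log units; beyond the scatter) on that step, so a ring in the group at this position does not by itself go with the higher number of compound 3. No measurement at hand accounts for these differences.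

Still open, on these data alone, is whether the number of compound 4 depends on the trifluoromethyl or on the closed ring alone, a question that the unsubstituted five-membered carbamate ring or its methyl analogue would address. Also open, as far as these compounds go, are the opposite configuration at the stereocentre and a cyclic urea, with a ring nitrogen bearing hydrogen in place of the ring oxygen.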